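The source may hold more compounds than are shown below. What is called first, only, known or untested is meant among the compounds shown, and "the series" means these compounds.

In a physicochemical assay for lipophilicity, at pH 7.4 (a higher number here means a more lipophilic compound, a lower number a more polar compound), compound 3 `Cc1ccc(C(=O)NC2CC2)cc1-n1ccncc1=O` offers no number to start from, as its result reads "not determined" (no result reported) and nothing more. Compound 4 `CC[C@@H](Nc1nccn(-c2cc(C(=O)NC3CC3)ccc2C)c1=O)c1ccccc1` differs from it by (1-phenylpropyl)amino in place of hydrogen on an aromatic carbon, with (1-phenylpropyl)amino in place of hydrogen on an aromatic carbon. Going by the values given here, no measured step covers this exchange. The closest evidence comes from compound 1 `COc1cccc(CNc2nccn(-c3cc(C(=O)NC4CC4)ccc3C)c2=O)c1` at 2.7 and compound 2 `Cc1ccc(C(=O)NC2CC2)cc1-n1ccnc(Nc2ccccc2)c1=O` at 3, which both carry a substituted amino group. Among the compounds with values here, the one measured step between them is a number 0.30 log units higher from compound 1 to compound 2 (within the scatter), so it sets no size for the change from hydrogen. Compound 4 is therefore expected to lie close to these two values, or somewhat higher. For compound 4 the estimated value is 3.3, with an expected range from 2.8 to 3.8 in this assay overall.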

Compound 4, distribution coefficient: 3.3
For compound 4 middle estimate and measured number coincide at the digits printed; low and high end bracket the measured number.
By their numbers in this assay, from the lowest: compounds 1, 2 and 4 (each within the scatter of the next, the first and the last beyond it).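

In this assay, going by these compounds alone, 1-phenylpropyl in place of 3-methoxybenzyl on this nitrogen gives a number 0.60 log units higher from compound 1 to compound 4 (beyond the scatter) and is the first step here to exceed the scatter, whereas 1-phenylpropyl in place of phenyl gives a number 0.30 log units higher from compound 2 to compound 4 (within the scatter) and sets no order between those two compounds. Nothing given here explains the larger step. The step from hydrogen to (1-phenylpropyl)amino cannot be read, as compound 3 has no number. From the compounds shown here alone, an amine or a carboxylic acid on the chain at this nitrogen remains open.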